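Aryl replacement at the pyrazole core: compound 2 to compound 3

The compounds below may be only part of what the source reports. "The series", "measured", "known", "first", "only" and "open" are said of these compounds alone.

Measured so far in a functional assay on BJAB cells (Homo sapiens) for antiproliferative activity, with a stated time of 4 days; on this read-out lower numbers stand for an effect already at smaller amounts and higher numbers for an effect only at larger amounts of compound:
- compound 1 `COc1cc(-c2c(C)nn(-c3nc(-c4ccc(Cl)c(Cl)c4)c(SC(C)C)s3)c2C(=O)O)cc(C(F)(F)F)c1`: 1380 nM
- compound 2 `Cc1nn(-c2nc(-c3ccc(Cl)c(Cl)c3)c(SC(C)C)s2)c(C(=O)O)c1-c1cncnc1`: 22000 nM

Compound 2 carries the highest number of the two in this assay; its nearest neighbour is compound 1, separated by a step beyond the scatter. The next compound, compound 3 `COc1ccc(-c2c(C)nn(-c3nc(-c4ccc(Cl)c(Cl)c4)c(SC(C)C)s3)c2C(=O)O)cc1`, differs from compound 2 by 4-methoxyphenyl in place of pyrimidin-5-yl on an aromatic carbon. Going by the values given here, only one measured step bears on this change: a 16-fold higher number from compound 1 to compound 2 (1.20 log units; beyond the scatter), which was large and beyond the scatter, going from a carbon-only aryl ring to the pyrimidin-5-yl ring. Compound 3 restores a carbon-only aryl ring, so a step back in the opposite direction, of comparable size, is expected: an 11-fold lower number from compound 2 to compound 3 (1.04 log units; beyond the scatter). Compound 3 is therefore estimated at 2000 nM, with a range from 600 nM to 7000 nM.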

Compound 3, half-maximal effective concentration: 2100 nM
Compound 3: the middle estimate sits 1.1-fold (0.02 log units) below what was measured, and the stated range covers the measured number.
By their numbers in this assay, from the lowest: compounds 1 and 3 (each within the scatter of the next); then compound 2.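

In this assay the pyrimidin-5-yl ring now stands apart from two different carbon-only aryl rings, with a second step beyond the scatter (a 10-fold lower number from compound 2 to compound 3 (1.02 log units; beyond the scatter)). The two carbon-only rings do not separate from each other (a 1.5-fold higher number from compound 1 to compound 3 (0.18 log units; within the scatter)), so 4-methoxyphenyl and 3-methoxy-5-(trifluoromethyl)phenyl cannot be told apart at this position, although their substituents differ. Nothing measured on these compounds accounts for the gap between the pyrimidin-5-yl ring and the carbon-only rings.

Open, from the compounds shown here alone, is whether a ring with a single nitrogen, such as pyridin-3-yl, would read like pyrimidin-5-yl or like the carbon-only rings. Also open, going by these compounds, is how a carbon-only aryl ring carrying an amine, such as 4-(dimethylamino)phenyl, would read at this position.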